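Working notes: aryl exchange from compound 3 to compound 4

The source may report more compounds than this note shows. Statements on the series, on what has been measured and on what is new or still open speak of the compounds shown alone.

- compound 1 `COc1cc(OC)c(OC)cc1/C=C/COC(=O)/C=C/c1ccc(Br)cc1`: 143 umol/kg
- compound 2 `COc1cc(OC)c(OC)cc1/C=C/COC(=O)/C=C/c1ccccc1C(F)(F)F`: 203 umol/kg
- compound 3 `COc1cc(OC)c(OC)cc1/C=C/COC(=O)/C=C/c1ccccc1Cl`: 151 umol/kg

All of these values come from a functional assay on the whole organism (strain Kunming) with Mus musculus as the target, with a stated time of 0.5 h; a lower number here means that less compound is needed, a higher number that more compound is needed for the effect. Compound 3 stands within the scatter of both other compounds, as shown by a 1.1-fold higher number from compound 1 to compound 3 (0.02 log units; within the scatter) and a 1.3-fold lower number from compound 2 to compound 3 (0.13 log units; within the scatter). Going by the values given here, the series so far therefore gives no separation.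

Compound 4 `COc1cccc(/C=C/C(=O)OC/C=C/c2cc(OC)c(OC)cc2OC)c1` has 3-methoxyphenyl in place of 2-chlorophenyl on a double-bonded chain carbon bound to a double-bonded chain carbon.

The measured steps that bear on this change are exchanges of the group at the same place. These are a 1.4-fold higher number from compound 1 to compound 2 (0.15 log units; within the scatter), together with the two steps above, and all of them stay within the scatter. Among the compounds with values here, none of the measured compounds carries 3-methoxyphenyl, so this remains an extrapolation, and the range is kept wider than the measured spread.

The expected change is a 1.1-fold higher number from compound 3 to compound 4 (0.03 log units; within the scatter), with no step beyond the scatter and no direction favoured. For compound 4 the estimated value in this assay is 160 umol/kg, with an expected range from 90 umol/kg to 280 umol/kg.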

Compound 4, dose for half-maximal effect: 190 umol/kg
Estimate against measurement, compound 4: 1.2-fold (0.07 log units) below, and the stated range covers the measured number.
By their numbers in this assay, from the lowest: compounds 1, 3, 4 and 2 (each within the scatter of the next).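

In this assay, exchanging 2-chlorophenyl for 3-methoxyphenyl, which adds one hydrogen-bond acceptor at this place, gives a 1.3-fold higher number from compound 3 to compound 4 (0.10 log units; within the scatter) and thus no separation. Set against the other two aryl groups, the same group gives a 1.1-fold lower number from compound 2 to compound 4 (0.03 log units; within the scatter) and a 1.3-fold higher number from compound 1 to compound 4 (0.12 log units; within the scatter), so an oxygen-bearing substituent now joins the chloro, bromo and trifluoromethyl groups without any step leaving the scatter. No evidence is available that could account for this flat picture.

The compounds shown leave open whether any exchange at this place moves the number beyond the scatter, for example a phenyl ring carrying an amine or a carboxylic acid. They also leave open whether moving one substituent around the phenyl ring matters, as each substituent appears here at a single ring place.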